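The source may report more compounds than this note shows. Statements on the series, on what has been measured and on what is new or still open speak of the compounds shown alone.

In an ADME assay on HEK293 cells (Homo sapiens) for cytotoxicity, read by MTT assay, with a stated time of 48 h (a higher number here means a weaker inhibitor, a lower number a stronger inhibitor), compound 1 (`CN(C)CCn1c(N)c(-c2nc3ccccc3n2C)c2nc(C#N)c(C#N)nc21`) gives > 50000 nM as a limit of the assay, not a number. Within the data shown here, compound 2 (`CCN(CC)CCn1c(N)c(-c2nc3ccccc3n2C)c2nc(C#N)c(C#N)nc21`) stands at 25400 nM as the only true number so far. Going to compound 3 (`CCN(CC)CCCn1c(N)c(-c2nc3ccccc3n2C)c2nc(C#N)c(C#N)nc21`), 2-(diethylamino)ethyl gives way to 3-(diethylamino)propyl ((diethylamino)methyl in place of diethylamino on a saturated chain carbon, two bonds along the chain from an aromatic nitrogen) on the shared core. Among the measured compounds shown here, the only measured step bearing on this (an at least 1.9-fold lower number from compound 1 to compound 2 (0.29 log units; that floor lies within the scatter)) stays within the scatter. That step starts from the limit of compound 1 (the limit of > 50000 nM in this assay, at which 1 of the 2 values shown sits) and so gives only a floor. In this assay no change beyond the scatter is therefore expected. The expected step (a 1.3-fold lower number from compound 2 to compound 3 (0.10 log units; within the scatter)) is small, toward a slightly lower number. For compound 3 the estimate is 20000 nM with a range of 9000 nM to 45000 nM as expected bounds.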

Compound 3, half-maximal inhibitory concentration: 7240 nM
Beside the measured number, compound 3's estimate is 2.8-fold (0.44 log units) above it; measured number below the stated range.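

In this assay, among these compounds, going from 2-(diethylamino)ethyl to 3-(diethylamino)propyl gives the first single change that clearly registers at this position: a 3.5-fold lower number from compound 2 to compound 3 (0.55 log units; beyond the scatter). The wider comparison also clears the scatter: an at least 6.9-fold lower number from compound 1 to compound 3 (0.83 log units; beyond the scatter). Compound 1 is a limit of the assay, so this step gives only a floor: the limit of > 50000 nM in this assay, at which 1 of the 3 values shown sits.

On these data alone, whether the number keeps falling with a longer chain, such as 4-(diethylamino)butyl, remains open. Also open, as far as these compounds go, is how a morpholine or piperidine in place of diethylamino on the propyl chain would read.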